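A Weak Series and a New Group on the Ring Nitrogen

The compounds below may be only part of what the source reports. "The series", "measured", "known", "first", "only" and "open" are said of these compounds alone.

Measured compounds:
compound 1 `CCOC(=O)C1=Cc2ccccc2OC1(OCc1cc(-c2ccc3ccccc3c2)no1)C(F)(F)F`, in a functional assay on MCF7 cells (Homo sapiens) for inhibition, read by MTT assay, with a stated time of 24 h (a lower number here means a stronger inhibitor, a higher number a weaker inhibitor), compound 1 gives 65400 nM;
compound 2 `CCOC(=O)C1=Cc2ccccc2OC1(OCc1cn(-c2ccccc2)nn1)C(F)(F)F`, in this assay compound 2 gives > 150000 nM, which is a limit of the assay and not a number;
compound 3 `O=C(O)C1=Cc2ccccc2OC1(OCc1cc(-c2ccc3ccccc3c2)no1)C(F)(F)F`, in this assay compound 3 gives > 150000 nM, likewise a limit.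

Compound 2 therefore stands at the ceiling of what this assay can report, as does compound 3 (the limit of > 150000 nM in this assay, at which 2 of the 3 values shown sit). Only compound 1 gives a number, and it is already a weak one.

Compound 4 `CCOC(=O)C1=Cc2ccccc2OC1(OCc1cn(CC(=O)Nc2ccc(OC)cc2)nn1)C(F)(F)F` has not yet been measured. The change ((4-methoxyphenyl)carbamoyl)methyl in place of phenyl on an aromatic nitrogen touches the aromatic nitrogen of the five-membered aromatic ring with 3 nitrogen. For the measured compounds named here, the one measured step, an at least 2.2-fold higher number from compound 1 to compound 3 (0.36 log units; beyond the scatter), concerns a different place, the oxygen next to the carbonyl group, so no measured step bears on this change. With compound 2 at a limit, the expected step of an at least 1.2-fold lower number from compound 2 to compound 4 (0.09 log units; that floor lies within the scatter) is best taken as none beyond the scatter, in an unknown direction. Compound 4 is estimated at 120000 nM, within 40000 nM to 300000 nM.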

Compound 4, half-maximal inhibitory concentration: 28100 nM
Estimate against measurement, compound 4: 4.3-fold (0.63 log units) above; the whole stated range lies above it.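

For the compounds shown here, until now, the only step that could be read concerned a different place, so the earlier compounds said nothing about the aromatic nitrogen of the five-membered aromatic ring with 3 nitrogen. In this assay, this position proves sensitive to what it carries: ((4-methoxyphenyl)carbamoyl)methyl in place of phenyl gives an at least 5.3-fold lower number from compound 2 to compound 4 (0.72 log units; beyond the scatter), although the new group keeps one six-membered aromatic ring of carbon only and adds 1 hydrogen-bond donor and 2 hydrogen-bond acceptors. The true size of this step is unknown because compound 2 gives only a limit: the limit of > 150000 nM in this assay, at which 2 of the 4 values shown sit.

As far as these compounds go, whether a chlorine or an amine in place of the methoxy, or a longer chain carrying the amide, would give a lower number remains open. Also open, from the compounds shown here alone, is how this new group behaves with a carboxylic acid in place of the ethyl ester.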